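The source may hold more compounds than are shown below. What is called first, only, known or untested is meant among the compounds shown, and "the series" means these compounds.

Three compounds measured in an assay on isolated protein for displacement of a labelled ligand from metabotropic glutamate receptor 5 (Rattus norvegicus) (a higher number here means a weaker inhibitor, a lower number a stronger inhibitor), share a core built around an oxime carbamate flanked by two cyclohexyl groups, and they differ in the aryl on the carbamate and in the group carried on the benzylic carbon. Among the compounds with values here, compound 1 `O=C(Nc1ccccc1)O/N=C(\C1CCCCC1)C(CN1CCc2ccccc2C1)C1CCCCC1` returns only a limit in this assay, > 1000 nM, and this is the one value that sits at the limit of > 1000 nM in this assay, at which 1 of the 3 values shown sits, rather than giving a number. Compound 2 `O=C(Nc1cccc(Cl)c1)O/N=C(\C1CCCCC1)C(Cc1cc[nH]c1)C1CCCCC1` gives 16.1 nM in this assay. Compound 3 `O=C(Nc1cccc(F)c1)O/N=C(\C1CCCCC1)C(Cc1cccs1)C1CCCCC1` gives 12.3 nM in this assay, and the two numbers for compound 2 and compound 3 lie within the scatter of each other, so neither can be put ahead of the other.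

Compound 4 `COc1cccc(NC(=O)O/N=C(\C2CCCCC2)C(Cc2cccs2)C2CCCCC2)c1` is the next compound and has not yet been measured in this assay. It differs from compound 3 by methoxy in place of fluoro on an aromatic carbon, so the change is methoxy in place of fluoro on an aromatic carbon of the carbamate aryl. Within the data shown here, no measured pair in this set shows such a swap, so there is no direct guide to its size. Compound 4 is expected to stay near compound 3, with a step of a 1.2-fold higher number from compound 3 to compound 4 (0.09 log units; within the scatter) that is estimated to fall within the usual scatter. The estimate for compound 4 in this assay is 15 nM, within the range 5 nM to 50 nM.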

Compound 4, inhibition constant: 88 nM
Compound 4: the middle estimate sits 5.9-fold (0.77 log units) below what was measured; the whole stated range lies below it.
By their numbers in this assay, from the lowest: compounds 3 and 2 (each within the scatter of the next); then compound 4. At a limit, above all of these: compound 1.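

In this assay the substituent on the carbamate aryl matters: putting methoxy in place of fluoro, meta to a large group, gives a 7.2-fold higher number from compound 3 to compound 4 (0.85 log units; beyond the scatter) and so moves the number beyond the scatter. Within the data shown here, the earlier compounds changed this aryl only together with the group on the benzylic carbon, so this pair is the first to isolate a substituent on that ring, with the rest of the molecule unchanged. Among these compounds, nothing at hand accounts for the size of this step, and the single swap gives no grounds for a reason.

Going by these compounds, it remains open whether the step belongs to methoxy alone, since a methyl, a hydroxyl, a chlorine or no substituent at all at this place on compound 3 could stay close to compound 3 or move towards compound 4. On these data alone, it is also open whether the same swap would give a step of similar size with the other benzylic group of compound 2, or whether the effect holds only alongside the benzylic group that compound 3 and compound 4 share.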